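Geometric isomer of a benzylidene oxindole glycoconjugate

This account rests on a few compounds, and the source may have more. Where it says the series, first, only, none or still open, it means among the compounds named here.

Measured compounds:
compound 1, `COc1ccc2c(c1)c(C=O)cn2Cc1cn([C@@H]2O[C@H](COC(C)=O)[C@@H](OC(C)=O)[C@H](OC(C)=O)[C@H]2OC(C)=O)nn1`: 106000 nM
compound 2, `CC(=O)OC[C@H]1O[C@@H](n2cc(CN3C(=O)/C(=C\c4ccccc4)c4ccccc43)nn2)[C@H](OC(C)=O)[C@@H](OC(C)=O)[C@@H]1OC(C)=O`: 17900 nM

Two compounds have been examined in a functional assay on A549 cells (Homo sapiens) for cytotoxicity, read by sulforhodamine B assay, with a stated time of 48 h; a higher number here means a weaker inhibitor, a lower number a stronger inhibitor. Compound 1 gives 106000 nM in this assay. Compound 2, with the same acetylated sugar and triazole linker, gives 17900 nM in this assay, the lower of the two numbers; the gap to compound 1 is beyond the usual scatter, so compound 2 is the stronger inhibitor of the pair.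

Compound 3, `CC(=O)OC[C@H]1O[C@@H](n2cc(CN3C(=O)/C(=C/c4ccccc4)c4ccccc43)nn2)[C@H](OC(C)=O)[C@@H](OC(C)=O)[C@@H]1OC(C)=O`, is the geometric isomer of compound 2: the two compounds have the same atoms and bonds and differ only in configuration as drawn: 1 of 6 stereo elements differ; a double bond is drawn Z in compound 2 and E in compound 3. Going by the values given here, no pair of measured compounds differing only in this way is available, so the size of the step cannot be read from the data. Compound 3 is expected to lie close to compound 2, with the step of a 1.2-fold higher number from compound 2 to compound 3 (0.09 log units; within the scatter) estimated as no more than the scatter in either direction. In this assay compound 3 is therefore estimated at 22000 nM, in the range 7000 nM to 70000 nM.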

Compound 3, half-maximal inhibitory concentration: 20600 nM
The estimate for compound 3 lay 1.1-fold (0.03 log units) above the measured number; measured number inside the range.
By their numbers in this assay, from the lowest: compounds 2 and 3 (each within the scatter of the next); then compound 1.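

The earlier compounds shown here offered no pair that differed in only one place, and compound 2 with compound 3 supplies the first. In this assay, changing the benzylidene double bond from Z to E gives a 1.2-fold higher number from compound 2 to compound 3 (0.06 log units; within the scatter), so the configuration drawn at this double bond makes no difference that can be told from the scatter. The comparison isolates this one feature, since nothing else separates the pair: the fact that compounds 2 and 3 differ only in the configuration as drawn

The compounds shown leave open whether the double-bond configuration would stay as silent with a chlorine or an amine added to the benzylidene group. They also leave open whether the same holds with free hydroxyl groups on the sugar in place of the acetyl groups.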